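Shortening the Chain on an Amine

The compounds below may be only part of what the source reports. "The series", "measured", "known", "first", "only" and "open" are said of these compounds alone.

In an ADME assay on L6 cells (Rattus norvegicus) for cytotoxicity (on this read-out higher numbers stand for weaker inhibition and lower numbers for stronger inhibition), compound 1 (`C/C=C(/C)C(=O)OC(C)c1cc2c(cc1OC)OC(C)(C)C=C2`) gives 139000 nM as its reading, while compound 2 (`COc1cc2c(cc1C(C)NC/C=C/c1ccccc1)C=CC(C)(C)O2`) gives 14600 nM as its reading. Compound 2 thus holds the lower of the two numbers, with a gap beyond the usual scatter of repeat measurements, so it is the stronger inhibitor of this pair.

Compound 3 (`CCNC(C)c1cc2c(cc1OC)OC(C)(C)C=C2`) keeps the shared core and the amine nitrogen of compound 2. The change is methyl in place of 2-phenylethenyl on a saturated chain carbon bound to an amine nitrogen and amounts to methyl in place of 2-phenylethenyl on a saturated chain carbon bound to an amine nitrogen. Within the data shown here, no measured pair shows this change on its own, so any forecast is rough. Among the measured compounds shown here, compound 2 at 14600 nM is the only amine with a number so far, and compound 1 at 139000 nM sits on the weak side. In this assay a move toward weaker inhibition, beyond the scatter, is expected, and the estimated size is a 3.4-fold higher number from compound 2 to compound 3 (0.53 log units; beyond the scatter) for this edit. For compound 3 the estimated value is 50000 nM with an expected range from 18000 nM to 140000 nM in this measurement.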

Compound 3, half-maximal inhibitory concentration: 176000 nM
For compound 3 the middle estimate is 3.5-fold (0.55 log units) below the measured one; measured number above the stated range.
By their numbers in this assay, from the lowest: compound 2; then compounds 1 and 3 (each within the scatter of the next).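

In this assay, putting methyl in place of 2-phenylethenyl on a saturated chain carbon bound to an amine nitrogen gives a 12-fold higher number from compound 2 to compound 3 (1.08 log units; beyond the scatter) as a large move toward weaker inhibition, so this position clearly responds to what is attached there. Putting ethylamino in place of ((1-methylprop-1-en-1-yl)carbonyl)oxy gives a 1.3-fold higher number from compound 1 to compound 3 (0.10 log units; within the scatter) and leaves the two readings indistinguishable, so among these compounds the amine nitrogen alone does not bring the lower number seen for compound 2, which also carries the 2-phenylethenyl group. The data shown offer no measurement that explains why the 2-phenylethenyl group makes this difference.

The step removes a six-membered aromatic ring, a double bond outside that ring and most of the chain all at once, so it cannot say which of these features counts. A saturated 2-phenylethyl group would test the double bond, while a benzyl group on the amine nitrogen or a simple longer chain such as n-butyl would help separate the part played by the aromatic ring from that of chain length.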